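A few compounds are considered here, and "the series" means these few. Any claim that something is new, unique, unknown or untested is made for them only; others in the source may bear on it.

The measured compounds:

Compound 1, `COc1ccccc1/C=C/C(=O)OC/C=C/c1cc(OC)c(OC)cc1OC`: in a functional assay on the whole organism (strain Kunming) with Mus musculus as the target, with a stated time of 0.5 h, at a dose of 300 mg/kg by the intraperitoneal route (a higher number here means a weaker effect of the compound at the dose given, a lower number a stronger effect), compound 1 gives 50%.
Compound 2, `COc1cc(OC)c(OC)cc1/C=C/COC(=O)/C=C/c1ccccc1C(F)(F)F`: in this assay compound 2 gives 50%.
Compound 3, `COc1cc(OC)c(OC)cc1/C=C/COC(=O)/C=C/c1cccc(Br)c1`: in this assay compound 3 gives 25%.

Compound 3 stands lowest of the three numbers. Its nearest neighbour is compound 1, and the step of a number 25 percentage points lower from compound 1 to compound 3 (beyond the scatter) lies beyond the scatter; compound 2 is the furthest, with a number 25 percentage points lower from compound 2 to compound 3 (beyond the scatter) of the same size. Between compound 1 and compound 2 there is no change at the digits printed from compound 1 to compound 2 (within the scatter).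

Compound 4 is `COc1cc(OC)c(OC)cc1/C=C/COC(=O)/C=C/c1ccccc1Cl`. Its difference from compound 3 is 2-chlorophenyl in place of 3-bromophenyl on a double-bonded chain carbon bound to a double-bonded chain carbon. Going by the values given here, no measured step involves a 2-chlorophenyl group, so the expectation rests on the two steps that lead into compound 3: in both, a 3-bromophenyl group replaced a phenyl group carrying a single group at the 2-position, and the number fell by the same modest amount each time. Compound 4 again carries a single group at the 2-position of the phenyl ring, so the step is expected to run the other way, back towards the numbers of compound 1 and compound 2, with a number 20 percentage points higher from compound 3 to compound 4 (beyond the scatter) estimated. For compound 4 the expected value in this assay is 45%, within a range of 25% to 65%.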

Compound 4, a percentage reported as activity, at one dose (the size of the read-out at that dose, not a potency): 25%
For compound 4 the middle estimate is 20 percentage points above the measured one, within the range that was stated.
By their numbers in this assay, from the lowest: compounds 3 and 4 (each within the scatter of the next); then compounds 1 and 2 (each within the scatter of the next).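

In this assay, exchanging the 3-bromophenyl group for 2-chlorophenyl at this place on the double-bonded chain carbon gives no change at the digits printed from compound 3 to compound 4 (within the scatter), so the low number seen earlier is not tied to the 3-bromophenyl group alone. On the same aromatic carbon, chloro parts from the two groups tested there before: replacing methoxy gives a number 25 percentage points lower from compound 1 to compound 4 (beyond the scatter), and replacing trifluoromethyl gives a number 25 percentage points lower from compound 2 to compound 4 (beyond the scatter). The earlier compounds shown here could be read as showing that a phenyl group numbered at 2 goes with the higher number, but compound 4 goes against that reading, which now holds only for the 2-methoxyphenyl group of compound 1 and the 2-(trifluoromethyl)phenyl group of compound 2.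

No measurement at hand accounts for chloro and methoxy differing on this carbon. As far as these compounds go, it remains open whether the outcome follows the identity of the group or its place on the ring, which a pair such as 2-bromophenyl and 3-chlorophenyl could separate, and how a ring bearing an amine or a carboxylic acid would read at this dose.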